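Notes on the sulfonamide series: step to compound 3

The source may report more compounds than this note shows. Statements on the series, on what has been measured and on what is new or still open speak of the compounds shown alone.

- compound 1 (`O=S(=O)(Nc1ccc(F)c(Cl)c1)c1ccc(-c2cnc(C3CC3)o2)cc1`) gives 73700 nM
- compound 2 (`O=S(=O)(Nc1cccc(Cl)c1)c1ccc(-c2cnc(C3CC3)o2)cc1`) gives 54200 nM
- compound 3 (`Cc1cc(NS(=O)(=O)c2ccc(-c3cnc(C4CC4)o3)cc2)ccc1Cl`) is not yet measured

All values come from a functional assay on cells (leukaemia cell line, Homo sapiens) for inhibition, read by sulforhodamine B assay, with a stated time of 48 h; on this read-out higher numbers stand for weaker inhibition of growth and lower numbers for stronger inhibition of growth. Going by the values given here, only two compounds have been measured so far, and compound 2 (54200 nM) cannot be separated from compound 1 (73700 nM) on these numbers. The next change is 4-chloro-3-methylphenyl in place of 3-chlorophenyl on a sulfonamide nitrogen.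

Among the compounds with values here, one measured step bears on this change: a 1.4-fold lower number from compound 1 to compound 2 (0.13 log units; within the scatter), with hydrogen in place of fluoro on an aromatic carbon. Within the data shown here, that step also falls on the group attached to the sulfonamide nitrogen, but it involves a different substituent, and no measured step covers a methyl group. The guide is therefore thin. Resting on that single step, and on compound 2 at 54200 nM, no shift beyond the scatter is expected in either direction in this assay. The expected step is a 1.1-fold higher number from compound 2 to compound 3 (0.04 log units; within the scatter) (an estimate only). The estimate for compound 3 is 60000 nM (expected range 28000 nM to 100000 nM).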

Compound 3, concentration for total growth inhibition: 33400 nM
Beside the measured number, compound 3's estimate is 1.8-fold (0.25 log units) above it; the measured number falls inside the stated range.
By their numbers in this assay, from the lowest: compounds 3, 2 and 1 (each within the scatter of the next, the first and the last beyond it).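

In this assay, the group on the sulfonamide nitrogen now gives its first step beyond the scatter: a 2.2-fold lower number from compound 1 to compound 3 (0.34 log units; beyond the scatter), with 4-chloro-3-methylphenyl in place of 3-chloro-4-fluorophenyl. The change from 3-chlorophenyl to 4-chloro-3-methylphenyl stays within the scatter at a 1.6-fold lower number from compound 2 to compound 3 (0.21 log units; within the scatter), so the methyl-bearing group cannot be separated from the 3-chlorophenyl group, and only the modest gap to compound 1 can be read. Nothing measured here accounts for either step.

The three groups on the sulfonamide nitrogen carry only chloro, fluoro and methyl substituents, so these compounds do not show how far this position can move the number in this assay. Still open, as far as these compounds go, is whether an amine, a carboxylic acid or a methoxy group on this phenyl ring, or an ethyl or longer alkyl chain in place of the methyl, would give a step from compound 3 beyond the scatter, and whether any change to the shared core would do the same.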